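Trimming a Methoxy Group from a Hydroxamic Acid Inhibitor

The source may hold more compounds than are shown below. What is called first, only, known or untested is meant among the compounds shown, and "the series" means these compounds.

Of the compounds shown here, three have been tested in an assay on isolated protein for inhibition of histone deacetylase 8 (Homo sapiens); a lower number here means a stronger inhibitor, a higher number a weaker inhibitor. Compound 1 `Cc1ccc(C(=O)c2ccc3c(ccn3Cc3ccc(C(=O)NO)cc3)c2)cc1` gives 1490 nM in this assay. Compound 2 `COc1ccc(C(=O)c2ccc3c(ccn3S(=O)(=O)c3cccc(/C=C/C(=O)NO)c3)c2)cc1OC` gives 1420 nM. Compound 3 `COc1cc(C(=O)c2ccc3c(ccn3Cc3ccc(/C=C/C(=O)NO)cc3)c2)cc(OC)c1OC` gives 2170 nM. Among these three numbers compound 2 stands lowest, but its nearest neighbour, compound 1, and its furthest, compound 3, both lie within the scatter of repeated measurements, so the three cannot be placed in any order of strength.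

Compound 4 `COc1cccc(C(=O)c2ccc3c(ccn3S(=O)(=O)c3cccc(/C=C/C(=O)NO)c3)c2)c1` has not yet been measured in this assay. It is reached from compound 2 by a single change: hydrogen in place of methoxy on an aromatic carbon The same difference, cut one bond further out, reads (3,4-dimethoxyphenyl)carbonyl to (3-methoxyphenyl)carbonyl.

For the measured compounds named here, no pair of measured compounds shows the effect of such a change, so the expectation rests on the narrow spread of the three numbers and the small size of the change. The step is expected to be a 1.1-fold higher number from compound 2 to compound 4 (0.05 log units; within the scatter), no larger than the scatter in either direction. On that basis compound 4 is estimated at 1600 nM, within a range from 600 nM to 4500 nM.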

Compound 4, half-maximal inhibitory concentration: 3530 nM
Estimate against measurement, compound 4: 2.2-fold (0.34 log units) below, and the stated range covers the measured number.
By their numbers in this assay, from the lowest: compounds 2, 1, 3 and 4 (each within the scatter of the next, the first and the last beyond it).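

In this assay, for the compounds shown here, the change from 3,4-dimethoxyphenyl to 3-methoxyphenyl gives a 2.5-fold higher number from compound 2 to compound 4 (0.40 log units; beyond the scatter), the first step between two compounds differing in one place. The earlier compounds shown here differ in several places at once and their numbers lie within the scatter of one another, so they could not show that this single methoxy group, ortho to a methoxy group and para to a large group, makes a measurable difference, though a modest one. Nothing available explains the rise in the number.

From the compounds shown here alone, it remains open whether a hydroxyl group, a fluorine atom or an ethoxy group at this position would keep the number near that of compound 2. Going by these compounds, it is also open whether removing a methoxy group would give a step of similar size on the core of compound 3.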